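Replacing a furan-2-yl end group with 2-hydroxy-3-methoxyphenyl

This account rests on a few compounds, and the source may have more. Where it says the series, first, only, none or still open, it means among the compounds named here.

Measured compounds:
Compound 1 `COc1cccc(CNCCCNc2ccnc3cc(-c4ccc(C(C)(C)C)cc4)ccc23)c1O` gives 690 nM in an ADME assay on HepG2 cells (Homo sapiens) for cytotoxicity, read by luminescence, CellTiter-Glo and ATP content, with a stated time of 72 h; a lower number here means that less compound is needed, a higher number that more compound is needed for the effect.
Compound 2 `COc1cccc(CNCCCNc2ccnc3cc(Cc4cc(C)cc(C)c4)ccc23)c1O` gives 2680 nM.
Compound 3 `Fc1ccc(Cc2ccc3c(NCCCNCc4ccco4)ccnc3c2)c(Cl)c1` gives 5730 nM.

Compound 3 stands highest of the three numbers; compound 2 is nearest to it, compound 1 furthest, and both gaps are beyond the scatter. Compound 4 `COc1cccc(CNCCCNc2ccnc3cc(Cc4ccc(F)cc4Cl)ccc23)c1O` differs from compound 3 in one place: 2-hydroxy-3-methoxyphenyl in place of furan-2-yl on a saturated chain carbon bound to an amine nitrogen.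

Among the compounds with values here, the only measured step, a 3.9-fold higher number from compound 1 to compound 2 (0.59 log units; beyond the scatter), changes the group on the core, not the amine end, so it does not bear directly on this change. What does bear on it is that compound 2 carries the same entering group on the same place and gives 2680 nM, a lower number than compound 3 with 5730 nM. On that basis a modest fall is expected, a 1.8-fold lower number from compound 3 to compound 4 (0.25 log units; within the scatter), rather than a step within the scatter. Compound 4 is therefore estimated at 3200 nM, with a range from 1200 nM to 8000 nM.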

Compound 4, half-maximal effective concentration: 2350 nM
Compound 4: the middle estimate sits 1.4-fold (0.13 log units) above what was measured; the range from low to high includes it.
By their numbers in this assay, from the lowest: compound 1; then compounds 4 and 2 (each within the scatter of the next); then compound 3.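

Swapping the end group alone, with the 2-chloro-4-fluorobenzyl group on the core held constant, gives a 2.4-fold lower number from compound 3 to compound 4 (0.39 log units; beyond the scatter) in this assay and is the first direct reading of this change at this position. The core group matters less clearly: 2-chloro-4-fluorophenyl in place of 3,5-dimethylphenyl gives a 1.1-fold lower number from compound 2 to compound 4 (0.06 log units; within the scatter) and leaves these two compounds indistinguishable. By contrast, 2-chloro-4-fluorobenzyl in place of 4-(tert-butyl)phenyl gives a 3.4-fold higher number from compound 1 to compound 4 (0.53 log units; beyond the scatter) and shows that the group on the core can still move the number as much as the end-group swap does.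

No measured evidence accounts for these steps. From the compounds shown here alone, it also remains open whether the hydroxyl or the methoxy goes with the fall, which an unsubstituted benzyl or a 3-methoxybenzyl end group could help to separate.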